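The source may report more compounds than this note shows. Statements on the series, on what has been measured and on what is new or still open speak of the compounds shown alone.

Measured so far in an ADME assay on MCF-10A cells (Homo sapiens) for cytotoxicity, read by sulforhodamine B assay, with a stated time of 48 h; a higher number here means a weaker inhibitor of growth, a lower number a stronger inhibitor of growth:

- Compound 1 `NC(=S)N/N=C1/C(=O)N(CN2CCN(c3ccnc4cc(Cl)ccc34)CC2)c2cccc(Cl)c21` gives 19800 nM
- Compound 2 `NC(=S)N/N=C1/C(=O)N(CN2CCN(c3ccnc4cc(Cl)ccc34)CC2)c2cc(Cl)ccc21` gives 64600 nM
- Compound 3 `NC(=S)N/N=C1/C(=O)N(CN2CCN(c3ccnc4cc(Cl)ccc34)CC2)c2cc(Br)ccc21` gives 22100 nM

Compound 3 stands second highest of the three numbers; its value sits within the scatter of compound 1 and well above that of compound 2, which is the only separation here beyond the scatter. The next structure, compound 4 `NC(=S)N/N=C1/C(=O)N(CN2CCN(c3ccnc4cc(Cl)ccc34)CC2)c2ccccc21`, differs from compound 3 by hydrogen in place of bromo on an aromatic carbon. Within the data shown here, only one measured step bears on a change at this position: a 2.9-fold lower number from compound 2 to compound 3 (0.47 log units; beyond the scatter). It shows that the halogen there does move this assay, but it does not show what the bare hydrogen does. Compound 4 is therefore expected to land near compound 3, with a guess of a 1.4-fold higher number from compound 3 to compound 4 (0.13 log units; within the scatter), at about 30000 nM (range 10000 nM to 90000 nM).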

Compound 4, concentration for 50% growth inhibition: 27700 nM
For compound 4 the middle estimate is 1.1-fold (0.03 log units) above the measured one; measured number inside the range.
By their numbers in this assay, from the lowest: compounds 1, 3 and 4 (each within the scatter of the next); then compound 2.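

In this assay, hydrogen in place of bromo gives a 1.3-fold higher number from compound 3 to compound 4 (0.10 log units; within the scatter), so the bromo is not needed for this level of growth inhibition. Hydrogen in place of chloro gives a 2.3-fold lower number from compound 2 to compound 4 (0.37 log units; beyond the scatter), which singles out the chloro of compound 2 as the group that goes with the weaker inhibition. Hydrogen in place of chloro elsewhere gives only a 1.4-fold higher number from compound 1 to compound 4 (0.15 log units; within the scatter), so the same swap does not act alike in both compounds.

No measurement here explains why these steps differ. From the compounds shown here alone, whether an amine or a methoxy group on this aromatic carbon would move the number remains open.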